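Notes on triazolylmethyl spirooxindoles in L02 cell viability

A few compounds are considered here, and "the series" means these few. Any claim that something is new, unique, unknown or untested is made for them only; others in the source may bear on it.

Measured compounds:
compound 1 `N#CC1=C(N)Oc2c(c3nc4ccccc4nc3c3ccccc23)C12C(=O)N(Cc1cnnn1-c1cccc(Cl)c1)c1ccccc12`
compound 2 `N#CC1=C(N)Oc2c(c3nc4ccccc4nc3c3ccccc23)C12C(=O)N(Cc1cnnn1-c1cccc(Br)c1)c1ccccc12`

In an ADME assay on L02 cells (Homo sapiens) for antiproliferative activity, read by MTT assay, with a stated time of 48 h (a higher number here means a weaker inhibitor, a lower number a stronger inhibitor), compound 1 gives 35200 nM. For compound 2 the assay reports only a limit, > 50000 nM, and compound 2 therefore stands at the edge of the measurable range (the limit of > 50000 nM in this assay, at which 1 of the 2 values shown sits). Going by the values given here, the single measured step, an at least 1.4-fold higher number from compound 1 to compound 2 (0.15 log units; that floor lies within the scatter), lies within the scatter. Compound 3 `CC(=O)Nc1ccc(-n2nncc2CN2C(=O)C3(C(C#N)=C(N)Oc4c3c3nc5ccccc5nc3c3ccccc43)c3ccccc32)cc1` differs from compound 2 by 4-acetamidophenyl in place of 3-bromophenyl on an aromatic nitrogen. Among the compounds with values here, no measured step covers such an exchange. No shift beyond the scatter is expected, and compound 3 is estimated at 50000 nM, with a range from 20000 nM to 120000 nM. The expected step is a number no higher from compound 2 to compound 3 (the limit leaves the size open).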

Compound 3, half-maximal inhibitory concentration: > 50000 nM
Compound 3 was reported as a limit; the forecaster's own chance of this, stated with the estimate: 55%; the middle value lies on the limit itself.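

On the aromatic nitrogen, 4-acetamidophenyl brings a hydrogen-bond donor and acceptor that the halophenyl groups lack, yet no measured number results. In this assay compound 3 is reported only as a limit, > 50000 nM. The exchange gives an at least 1.4-fold higher number from compound 1 to compound 3 (0.15 log units; that floor lies within the scatter), the step from compound 2 to compound 3 cannot be read, and the series now gathers at the edge of the range: the limit of > 50000 nM in this assay, at which 2 of the 3 values shown sit.

Open, from the compounds shown here alone, is whether an amine or a carboxylic acid on this phenyl ring would give a number inside the range. Going by these compounds, the actual values of compound 2 and compound 3 also stay open.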